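The source may hold more compounds than are shown below. What is called first, only, known or untested is meant among the compounds shown, and "the series" means these compounds.

This study asks whether a small set of compounds is toxic to cells, measured in an ADME assay on NCM460 cells (Homo sapiens) for cytotoxicity, read by MTT assay, with a stated time of 72 h; on this read-out lower numbers stand for stronger inhibition and higher numbers for weaker inhibition. Compound 1 `CCCCCN1C(=O)C/C(=C\c2cccc(C(=O)Nc3cccc(CC)c3)c2)C1=O` gives only a limit of the assay, > 100000 nM. Compound 2 `COc1ccc(OC)c(NC(=O)c2cccc(/C=C3\CC(=O)N(c4ccccc4)C3=O)c2)c1` likewise reaches only a limit, > 100000 nM. Compound 3 `O=C(Nc1ccc(Cl)cc1)c1cccc(/C=C2\CC(=O)N(Cc3ccccc3)C2=O)c1` also stops at a limit, > 100000 nM. So compound 2 stands at the limit of > 100000 nM in this assay, at which 3 of the 3 values shown sit, with no number of its own to compare against. Compound 4 `O=C(c1cccc(/C=C2\CC(=O)N(c3ccccc3)C2=O)c1)N1CCCC1` has not yet been measured. It differs from compound 2 in one place: pyrrolidin-1-yl in place of (2,5-dimethoxyphenyl)amino on a carbonyl carbon. Among the measured compounds shown here, no measured pair shows what such a change does in this assay. Compound 4 is expected to stay at a limit too, so the step that the limit leaves unreadable from compound 2 to compound 4 is estimated as none beyond the scatter. The estimate for compound 4 is 150000 nM, between 50000 nM and 500000 nM.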

Compound 4, half-maximal inhibitory concentration: > 100000 nM
Compound 4: no number, only a limit (the forecaster's own chance of this, stated with the estimate: 85%); the middle value lies beyond the limit too.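

Compound 2 and compound 4 both give only limits rather than numbers, so no step between them can be read: the limit of > 100000 nM in this assay, at which 4 of the 4 values shown sit.

The compounds shown leave open whether any change to the shared core would give a real number instead of a limit.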